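The source may hold more compounds than are shown below. What is called first, only, known or untested is meant among the compounds shown, and "the series" means these compounds.

Measured compounds in the series:
- compound 1 `Cc1ccsc1-c1ccccc1NCC1=NCCN1`: 0.851 nM
- compound 2 `Cc1ccc(-c2ccccc2NCC2=NCCN2)o1`: 2.69 nM

In a functional assay for activation of Alpha-1A adrenergic receptor (Homo sapiens), read by calcium flux (a higher number here means that more compound is needed for the effect, a lower number that less compound is needed), compound 1 gives 0.851 nM. In this assay, among the compounds with values here, compound 2 gives 2.69 nM, the higher of the two numbers measured so far; the only other compound, compound 1, sits at the lower end, with a 3.2-fold higher number from compound 1 to compound 2 (0.50 log units; beyond the scatter).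

Compound 3 `c1ccc(-c2ccccc2NCC2=NCCN2)nc1` has not been measured in this assay. It differs from compound 2 in one place: pyridin-2-yl in place of 5-methylfuran-2-yl on an aromatic carbon. One aromatic five-membered ring with one hetero atom leaves and a six-membered aromatic ring with one hetero atom enters, on the same aromatic carbon, ortho to a group of 7 heavy atoms.

Within the data shown here, the only measured step that bears on this change is the exchange of one five-membered aromatic ring for another, a 3.2-fold higher number from compound 1 to compound 2 (0.50 log units; beyond the scatter), a modest shift beyond the scatter. That step concerns a different pair of rings, so it sets only the scale of what a change at this position has done, not its direction. A step of similar size is therefore expected, in either direction, a 1.1-fold higher number from compound 2 to compound 3 (0.05 log units; within the scatter).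

Compound 3 is estimated at 3 nM in this assay, with a range from 0.8 nM to 12 nM.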

Compound 3, half-maximal effective concentration: 6.76 nM
For compound 3 the middle estimate is 2.3-fold (0.35 log units) below the measured one; measured number inside the range.
By their numbers in this assay, from the lowest: compound 1; then compound 2; then compound 3.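

Against the earlier five-membered rings, pyridin-2-yl gives a 2.5-fold higher number from compound 2 to compound 3 (0.40 log units; beyond the scatter) in this assay, so a six-membered aromatic ring at this position, ortho to a group of 7 heavy atoms, stays in the nanomolar range while moving further from compound 1. The step of a 7.9-fold higher number from compound 1 to compound 3 (0.90 log units; beyond the scatter) is the widest in the series, and both steps that start from the methyl-bearing five-membered rings and end at compound 3 run towards a higher number. The counted features do not separate compound 2 from compound 3, with 6 heavy atoms, 1 hetero atom and 1 hydrogen-bond acceptor on each side, yet the number still moves beyond the scatter. No accompanying data bear on the origin of this shift.

Compound 3 differs from compound 2 in ring size, hetero atom and the loss of the methyl group at once, so the contribution of each remains unresolved. A methyl-substituted pyridine or an unsubstituted phenyl ring at the same carbon would help separate these contributions, and a pyridin-3-yl ring would test where the ring nitrogen sits.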